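Swapping Dimethylamino for Chloro on the Dienone Scaffold

The source may hold more compounds than are shown below. What is called first, only, known or untested is meant among the compounds shown, and "the series" means these compounds.

Compound 1, `CN(C)c1ccc(/C=C2\CCC/C(=C\c3ccccc3[N+](=O)[O-])C2=O)cc1`: 168000 nM
Compound 2, `CN(C)c1ccc(/C=C2\CCC/C(=C\c3cccc([N+](=O)[O-])c3)C2=O)cc1`: 11700 nM
Compound 3, `O=C1/C(=C/c2ccccc2)CCC/C1=C\c1cccc([N+](=O)[O-])c1`: 2290 nM

All three compounds were tested in a functional assay on CCRF-CEM cells (Homo sapiens) for cytotoxicity, with a stated time of 72 h; on this read-out lower numbers stand for stronger inhibition and higher numbers for weaker inhibition. Compound 1 stands at the highest number of the three, which in this read-out means the weakest effect: the step of a 14-fold lower number from compound 1 to compound 2 (1.16 log units; beyond the scatter) and the further step a 5.1-fold lower number from compound 2 to compound 3 (0.71 log units; beyond the scatter) both move to lower numbers, each beyond the scatter of the measurement.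

Compound 4, `O=C1/C(=C/c2ccc(Cl)cc2)CCC/C1=C\c1ccccc1[N+](=O)[O-]`, has not been measured yet. It differs from compound 1 in one place: chloro in place of dimethylamino on an aromatic carbon. Among the measured compounds shown here, the only measured step that speaks to this is a 5.1-fold lower number from compound 2 to compound 3 (0.71 log units; beyond the scatter), where the same dimethylamino group left and a hydrogen entered; no measured pair shows chloro itself, and that step was taken on a different nitrophenyl partner. Taking that precedent as a guide, a modest move to a lower number is expected for compound 4, with wide uncertainty because only a 5.1-fold lower number from compound 2 to compound 3 (0.71 log units; beyond the scatter) supports it. Compound 4 is estimated at 35000 nM, within a range from 8000 nM to 120000 nM. The expected step is a 4.8-fold lower number from compound 1 to compound 4 (0.68 log units; beyond the scatter).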

Compound 4, half-maximal inhibitory concentration in the CCRF-CEM assay: 1750 nM
Beside the measured number, compound 4's estimate is 20-fold (1.30 log units) above it; the whole stated range lies above it.
By their numbers in the CCRF-CEM assay, from the lowest: compounds 4 and 3 (each within the scatter of the next); then compound 2; then compound 1.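

Among the compounds shown here, in the CCRF-CEM assay, chloro in place of dimethylamino gives a large step (a 96-fold lower number from compound 1 to compound 4 (1.98 log units; beyond the scatter)), which shows that this aromatic carbon matters strongly on the 2-nitrophenyl partner too, and with an entering group that the earlier compounds did not carry. In a physicochemical assay for lipophilicity (on this read-out lower numbers stand for lower lipophilicity and higher numbers for higher lipophilicity), compound 1 gives (4.86) and compound 4 gives (4.86), so the partition coefficient does not separate them (no change at the digits printed from compound 1 to compound 4 (within the scatter)), even though their cytotoxicity numbers lie far apart. Nothing measured here accounts for the size of the step in cytotoxicity. The compounds shown leave open whether chloro would give a step of similar size on the 3-nitrophenyl partner. They also leave open how other groups at this place, such as methoxy, fluoro or a carboxylic acid, would compare with chloro.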